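This account rests on a few compounds, and the source may have more. Where it says the series, first, only, none or still open, it means among the compounds named here.

Values so far in a functional assay on A549 cells (Homo sapiens) for inhibition, read by sulforhodamine B assay, with a stated time of 72 h; a lower number here means a stronger inhibitor of growth, a higher number a weaker inhibitor of growth
- compound 1 `CCOC(=O)/C=C/c1ccncc1-c1ccc2[nH]ccc2c1` gives 7440 nM
- compound 2 `CCOC(=O)/C=C/c1ccncc1-c1ccc2c(ccn2C)c1` gives 1720 nM
- compound 3 `COC(=O)/C=C/c1ccncc1-c1ccc2ccccc2c1` gives 760 nM

Among these three values, compound 2 sits in the middle, with a higher number than compound 3 and a lower number than compound 1. The next compound, compound 4 `CNC(=O)/C=C/c1ccncc1-c1ccc2c(ccn2C)c1`, alters compound 2 in one place: methylamino in place of ethoxy on a carbonyl carbon, so ethoxycarbonyl becomes methylcarbamoyl (methylamino in place of ethoxy on a carbonyl carbon). Among the measured compounds shown here, no measured step covers this change. For the measured compounds named here, the only step available is a 4.3-fold lower number from compound 1 to compound 2 (0.64 log units; beyond the scatter) and it is methyl in place of hydrogen on an aromatic nitrogen, which is a different change, so it offers only a sense of scale. With nothing measured at the carbonyl carbon, the direction is a judgement: a modest rise in the number, meaning a weaker inhibitor of growth, is expected, though a fall cannot be ruled out. In this assay the estimated step is a 2.3-fold higher number from compound 2 to compound 4 (0.37 log units; beyond the scatter) and serves only as a rough guide. The estimated value for compound 4 is 4000 nM with 1000 nM to 16000 nM as the expected range.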

Compound 4, concentration for 50% growth inhibition: 6450 nM
Estimate against measurement, compound 4: 1.6-fold (0.21 log units) below; the measured number falls inside the stated range.
By their numbers in this assay, from the lowest: compound 3; then compound 2; then compounds 4 and 1 (each within the scatter of the next).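

Among the compounds shown here, the earlier step touched only the aromatic nitrogen, so this is the first look at the carbonyl end of the side chain. In this assay, methylamino in place of ethoxy on the carbonyl carbon gives a 3.8-fold higher number from compound 2 to compound 4 (0.57 log units; beyond the scatter), so the group on this carbon does affect growth inhibition, and this swap yields a weaker inhibitor. The swap also changes several things at once, with one fewer heavy atom and a hydrogen-bond donor entering as a hydrogen-bond acceptor leaves, and nothing available explains the change in the number.

On these data alone, it remains open how other groups on this carbonyl carbon would fare, such as a hydroxy group, which would give the carboxylic acid, or a dimethylamino group. Also open, as far as these compounds go, is whether the same swap would produce a similar step on the core of compound 3.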